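The source may report more compounds than this note shows. Statements on the series, on what has been measured and on what is new or still open speak of the compounds shown alone.

In an ADME assay on microsomes from liver (Mus musculus) for metabolic stability, read by LC-MS, using NADPH, with a stated time of 30 min, tested at 1 uM (on this read-out lower numbers stand for a less stable compound and higher numbers for a more stable compound), compound 1 (`O=C(Oc1ccc(OCc2ccccc2)cc1)N(Cc1ccccc1)S(=O)(=O)c1ccc(Cl)cc1`) gives 53.4% and holds the lower of the two numbers, while compound 2 (`O=C(Nc1ccc(OCCCCc2ccccc2)cc1)N(Cc1ccccc1)S(=O)(=O)c1ccc(Cl)cc1`) gives 79% and the gap between them lies beyond the usual scatter. Compound 3 (`O=C(Oc1ccc(OCc2ccccc2)cc1)N(Nc1ccccc1)S(=O)(=O)c1ccc(Cl)cc1`) has not yet been measured. Compared with compound 1, it carries anilino in place of benzyl on an amide-type nitrogen. Among the measured compounds shown here, no measured pair shows this change, so the data give no direction for it. In this assay the expected step of a number 3.4 percentage points lower from compound 1 to compound 3 (within the scatter) is estimated to stay within the scatter. Compound 3 is therefore estimated at 50% with 27% to 73% as the expected range.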

Compound 3, percent of the compound remaining: 42.2%
Compound 3: the middle estimate sits 7.8 percentage points above what was measured; the range from low to high includes it.
By their numbers in this assay, from the lowest: compound 3; then compound 1; then compound 2.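

In this assay this position now has a direction (a number 11.2 percentage points lower from compound 1 to compound 3 (beyond the scatter)) when anilino replaces benzyl on the amide-type nitrogen. Both groups have the same heavy-atom count and one six-membered aromatic ring of carbon only, while anilino brings a nitrogen with a hydrogen-bond donor and a hydrogen-bond acceptor. Nothing available explains why the number moves this way. What the compounds shown leave open is whether phenethyl, a longer chain, or a simple methylamino group on this nitrogen would land with benzyl or with anilino. Also open, going by these compounds, is whether the same replacement would act alike on compound 2.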